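The source may hold more compounds than are shown below. What is called first, only, known or untested is meant among the compounds shown, and "the series" means these compounds.

Compounds measured so far, with their values in a functional assay on BXPC-3 cells (Homo sapiens) for antiproliferative activity, read by sulforhodamine B assay, with a stated time of 72 h; a lower number here means a stronger inhibitor, a higher number a weaker inhibitor:

compound 1 `CN(CCNCc1cn(-c2ccccc2)nn1)CCNc1ccnc2cc(Cl)ccc12`: 10000 nM
compound 2 `CN(CCNCc1cn(-c2ccc(Cl)cc2)nn1)CCNc1ccnc2cc(Cl)ccc12`: 9100 nM
compound 3 `CN(CCNCc1cn(-c2nc3ccccc3[nH]2)nn1)CCNc1ccnc2cc(Cl)ccc12`: 16000 nM

All three share the same core and differ only in the group that sits on the aromatic nitrogen of the triazole ring. Compound 3 carries the highest number of the three, yet the gaps to compound 1 and compound 2 are both within the scatter, so the three cannot be separated on these numbers. The steps tell the same story: a 1.1-fold lower number from compound 1 to compound 2 (0.04 log units; within the scatter), a 1.6-fold higher number from compound 1 to compound 3 (0.20 log units; within the scatter) and a 1.8-fold higher number from compound 2 to compound 3 (0.25 log units; within the scatter) are each within the scatter of this assay.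

Compound 4 `CN(CCNCc1cn(-c2ccnc3cc(Cl)ccc23)nn1)CCNc1ccnc2cc(Cl)ccc12` is the next step from compound 3: 7-chloroquinolin-4-yl in place of 1H-benzimidazol-2-yl on an aromatic nitrogen. For the measured compounds named here, the steps that bear on it are those in which this same group was exchanged, from phenyl to 4-chlorophenyl and from either of these to 1H-benzimidazol-2-yl, and none of them moved the number beyond the scatter. On that basis no step beyond the scatter is expected in this assay for compound 4, and the expected step is a 1.5-fold lower number from compound 3 to compound 4 (0.16 log units; within the scatter). The estimate for compound 4 in this assay is 11000 nM, with a range from 3500 nM to 35000 nM.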

Compound 4, half-maximal inhibitory concentration: 8800 nM
Estimate against measurement, compound 4: 1.3-fold (0.10 log units) above; the range from low to high includes it.
By their numbers in this assay, from the lowest: compounds 4, 2, 1 and 3 (each within the scatter of the next).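

In this assay, 7-chloroquinolin-4-yl on the aromatic nitrogen gives no step beyond the scatter from any of the three earlier groups: a 1.8-fold lower number from compound 3 to compound 4 (0.26 log units; within the scatter), a 1.0-fold lower number from compound 2 to compound 4 (0.01 log units; within the scatter) and a 1.1-fold lower number from compound 1 to compound 4 (0.06 log units; within the scatter). This adds a new kind of exchange at this position: the hydrogen-bond donor of 1H-benzimidazol-2-yl leaves, a group with no such donor and with a chlorine enters, and the number still stays within the scatter, so all four compounds remain inseparable in this assay. No measured information is available to explain this result.

Every group shown here is built from aromatic rings, so it remains open whether an amine, a carboxylic acid or a longer carbon chain on this nitrogen would give a step beyond the scatter. The rest of the shared core is the same in all four compounds, which leaves open how changes elsewhere in the molecule would affect the numbers.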